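The source may hold more compounds than are shown below. What is called first, only, known or untested is meant among the compounds shown, and "the series" means these compounds.

Compound 1 `O=C(O)Cc1sc(C(c2ccc(F)cc2)c2ccc(F)cc2)nc1-c1ccncc1` is measured in an in vitro assay on HEK385-7 cells for displacement of a labelled ligand from prostaglandin D2 receptor 2 (Homo sapiens) (a higher number here means a weaker inhibitor, a lower number a stronger inhibitor), where compound 1 gives 5.3 nM. Among the three compounds with a number, compound 1 holds the second highest. The nearest of the others is compound 2 `O=C(O)Cc1sc(C(c2ccccc2)c2ccccc2)nc1-c1cccc(F)c1`, which in this assay gives 2.9 nM; the two numbers lie within the scatter of each other, so nothing separates them. The furthest is compound 3 `O=C(O)Cc1sc(C(c2ccccc2)c2ccc(F)cc2)nc1-c1ccc(Cl)cc1`, which in this assay gives 17 nM, a higher number than that of compound 1 by more than the scatter allows.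

Compound 4 `CN(C)c1cc(-c2nc(C(c3ccc(F)cc3)c3ccc(F)cc3)sc2CC(=O)O)ccn1` has not been measured. It differs from compound 1 in one place: dimethylamino in place of hydrogen on an aromatic carbon. Cut one bond further out, the change reads pyridin-4-yl to 2-(dimethylamino)pyridin-4-yl. Among the compounds with values here, no measured pair shows this change, so there is no step to lean on. The expectation for compound 4 in this assay is therefore a step that stays within the scatter, or at most a small rise, and compound 4 is estimated at 8 nM, with a range from 2.5 nM to 30 nM, which means an expected step of a 1.5-fold higher number from compound 1 to compound 4 (0.18 log units; within the scatter).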

Compound 4, half-maximal inhibitory concentration: 380 nM
Beside the measured number, compound 4's estimate is 48-fold (1.68 log units) below it; the measured number lies above the stated range.
By their numbers in this assay, from the lowest: compounds 2 and 1 (each within the scatter of the next); then compound 3; then compound 4.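

Within the data shown here, the earlier compounds offered no step between two that differ in one place, so this is the first direct reading of a single change. In this assay, dimethylamino in place of hydrogen on the aromatic carbon next to the ring nitrogen, with the rest of compound 1 unchanged, gives a 72-fold higher number from compound 1 to compound 4 (1.86 log units; beyond the scatter), so this one position is far from indifferent to what it carries. Nothing measured here on these compounds accounts for the size of the step.

From the compounds shown here alone, whether the step belongs to dimethylamino itself or to any group at this place stays open: a methyl, an amino or a methoxy group on the same carbon would separate the two. Also open, going by these compounds, is whether dimethylamino on another carbon of the same ring would give a step of this size.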